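Swapping a pyridine for a pyrazole on a weak core

The source may report more compounds than this note shows. Statements on the series, on what has been measured and on what is new or still open speak of the compounds shown alone.

Three compounds have been measured in a functional assay on VCaP cells (Homo sapiens) for antiproliferative activity, read by CCK-8 assay, with a stated time of 6 days; on this read-out lower numbers stand for stronger inhibition and higher numbers for weaker inhibition:

compound 1, `N#Cc1ccc(N2CCc3cc(-c4cnc5ccccc5c4)ccc3C2)cc1C(F)(F)F`: > 30000 nM
compound 2, `CCN(c1ccc(C#N)c(Cl)c1)c1cc(-c2ccoc2)ccc1C`: 4010 nM
compound 3, `N#Cc1ccc(N2CCCc3c(-c4ccncc4)cccc32)cc1C(F)(F)F`: > 30000 nM

In this assay compound 1 reaches only > 30000 nM, which is a limit of the assay and not a number. Compound 2 gives a measured value of 4010 nM. For compound 3 the result is again a limit of the assay, > 30000 nM. Two of the three results therefore sit at the same ceiling (the limit of > 30000 nM in this assay, at which 2 of the 3 values shown sit), and compound 3 stands at that ceiling: its antiproliferative activity is too weak to be put into a number.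

The next compound, compound 4, `Cn1nccc1-c1cccc2c1CCCN2c1ccc(C#N)c(C(F)(F)F)c1`, is built on the core of compound 3 with one change: 1-methyl-1H-pyrazol-5-yl in place of pyridin-4-yl on an aromatic carbon. For the measured compounds named here, both groups are small aromatic rings with a similar number of heavy atoms, and no measured pair in this set shows what such a swap does in this assay. Since compound 3 is only known to lie at the limit, the most likely outcome is that compound 4 stays there too, so the expected step of a number no higher from compound 3 to compound 4 (the limit leaves the size open) is none beyond the scatter. Compound 4 is therefore estimated at 30000 nM, with a plausible range from 8000 nM to 100000 nM.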

Compound 4, half-maximal inhibitory concentration: > 30000 nM
Compound 4: only a limit was reported; the forecaster's own chance of this, stated with the estimate: 70%; the middle value lies on the limit itself.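

In this assay compound 4 gives > 30000 nM as a limit of the assay and not a number. For the compounds shown here, compound 3 also stands at a limit, and no step from compound 3 to compound 4 can be read. The compounds shown leave open how 1-methyl-1H-pyrazol-5-yl and pyridin-4-yl compare on this core in this assay when measured as actual numbers.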